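A few compounds are considered here, and "the series" means these few. Any claim that something is new, unique, unknown or untested is made for them only; others in the source may bear on it.

Compound 1 `Cc1c(OCCCCOc2ccc(C(=O)O)cc2)ccc(C(=O)CC2CCCC2)c1O` carries a cyclopentyl group at one end and a carboxyphenyl ether at the other. Within the data shown here, in an assay on HEK293 cells for positive allosteric modulation of metabotropic glutamate receptor 2 (Rattus norvegicus), read by thallium flux, with a stated time of 2.5 min (a higher number here means that more compound is needed for the effect, a lower number that less compound is needed), compound 1 gives 824 nM, the highest of the three numbers measured so far. Its nearest neighbour is compound 3 `Cc1c(OCCCCOc2cccc(C(=O)O)c2)ccc(C(=O)CC2CCCC2)c1O`, which gives 451 nM; the step of a 1.8-fold lower number from compound 1 to compound 3 (0.26 log units; within the scatter) stays within the scatter, so these two compounds cannot be told apart. Compound 2 `Cc1c(OCCCCOc2ccc(C(=O)O)cc2Cl)ccc(C(=O)CC2CCCC2)c1O` gives 237 nM, and the step of a 3.5-fold lower number from compound 1 to compound 2 (0.54 log units; beyond the scatter) is the only one that clearly stands out, while the step of a 1.9-fold higher number from compound 2 to compound 3 (0.28 log units; within the scatter) again stays within the scatter.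

Compound 4 `Cc1c(OCCCCOc2ccc(C(=O)O)cc2)ccc(C(=O)CC(C)C)c1O` differs from compound 1 at the other end of the molecule: isopropyl in place of cyclopentyl on a saturated chain carbon bound to a carbonyl carbon. Seen one bond further out, a cyclopentylmethyl becomes an isobutyl. None of the three measured steps touches this part of the structure; all of them change the carboxyphenyl end. Among the measured compounds shown here, there is thus no measured precedent for this change, and the expectation can only be that the number moves little, if at all, beyond the scatter. The step from compound 1 to compound 4 is estimated as a 1.6-fold higher number from compound 1 to compound 4 (0.20 log units; within the scatter). Compound 4 is therefore expected to give about 1300 nM, with a likely range from 500 nM to 3500 nM.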

Compound 4, half-maximal effective concentration: 122 nM
The estimate for compound 4 lay 11-fold (1.03 log units) above the measured number; the whole stated range lies above it.
By their numbers in this assay, from the lowest: compounds 4, 2, 3 and 1 (each within the scatter of the next, the first and the last beyond it).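

Until now, every measured step changed the carboxyphenyl end of the molecule, so nothing was known about the opposite end. In this assay the change at that end gives a 6.8-fold lower number from compound 1 to compound 4 (0.83 log units; beyond the scatter) and so shows that the number responds to the group on a saturated chain carbon bound to a carbonyl carbon. The ring of cyclopentyl is also not needed for a low number here, since isopropyl, with 3 heavy atoms and no ring, takes the place of cyclopentyl, with 5 heavy atoms, and the number falls; no available evidence bears on what lies behind this step.

On these data alone, with a single replacement at this place, it remains open whether the number follows the size of the group or the presence of a ring, and a methyl, a tert-butyl or a cyclohexyl group there would help to separate the two. It also remains open whether isopropyl and the chloro of compound 2 would add up when carried by one molecule, as no compound shown has both.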